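The compounds below may be only part of what the source reports. "The series", "measured", "known", "first", "only" and "open" are said of these compounds alone.

Working notes on the series. Three compounds share one core; compound 1 `Cc1cc(C(=O)O)nn1Cc1cc(Br)ccc1OCc1ccc(Cl)cc1Cl` gives 0.49 nM in a functional assay on CHO-K1 cells for antagonist activity at prostaglandin E2 receptor EP1 subtype (Homo sapiens), read by FLIPR (on this read-out lower numbers stand for stronger inhibition and higher numbers for weaker inhibition), compound 2 `Cc1cc(C(=O)O)nn1Cc1cc(Br)ccc1OCc1ccc(F)cc1F` gives 2.63 nM, and compound 3 `Cc1cc(C(=O)O)nn1Cc1cc(Br)ccc1OCc1ccc(F)cc1` gives 11.8 nM, the highest number of the three: a 24-fold higher number from compound 1 to compound 3 (1.38 log units; beyond the scatter) and a 4.5-fold higher number from compound 2 to compound 3 (0.65 log units; beyond the scatter) both lie beyond the scatter.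

Compound 4 `Cc1cc(C(=O)O)nn1Cc1cc(Br)ccc1OCc1c(F)cccc1F` is not yet measured. Its change from compound 3 is 2,6-difluorophenyl in place of 4-fluorophenyl on a saturated chain carbon bound to an oxygen on an aromatic ring, or, cut one bond further out, 4-fluorobenzyl to 2,6-difluorobenzyl. The nearest measured step is the loss of a fluoro on this ring, a 4.5-fold higher number from compound 2 to compound 3 (0.65 log units; beyond the scatter), and the wider comparison a 5.4-fold higher number from compound 1 to compound 2 (0.73 log units; beyond the scatter) shows the halogen pattern on this ring matters. Within the data shown here, no measured pair puts fluorine in the 2,6-arrangement, so the direction is carried over from the fluorine count alone: an estimate of a modest move to a lower number, a 2.4-fold lower number from compound 3 to compound 4 (0.37 log units; beyond the scatter), with a wide range because the pattern is untested. The estimate for compound 4 is 5 nM, between 1.2 nM and 25 nM.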

Compound 4, inhibition constant: 105 nM
Estimate against measurement, compound 4: 21-fold (1.32 log units) below; the whole stated range lies below it.
By their numbers in this assay, from the lowest: compound 1; then compound 2; then compound 3; then compound 4.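

Fluorine count alone does not set the number at this position: compound 2 and compound 4 each carry two fluoro groups, yet 2,6-difluorophenyl in place of 2,4-difluorophenyl gives a 40-fold higher number from compound 2 to compound 4 (1.60 log units; beyond the scatter) in this assay with the shared core unchanged. Compound 4 goes against the trend of more halogen giving a lower number across compound 1, compound 2 and compound 3, since 2,6-difluorophenyl in place of 4-fluorophenyl gives an 8.9-fold higher number from compound 3 to compound 4 (0.95 log units; beyond the scatter) and the replacement of 2,4-dichlorophenyl gives a 210-fold higher number from compound 1 to compound 4 (2.33 log units; beyond the scatter) as the widest gap in the series. No supporting data bear on why this arrangement behaves so.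

Going by these compounds, it remains open whether the rise in the number follows from the 2,6-arrangement of halogens in general or is particular to fluoro. A chloro or methoxy group on this ring in the same arrangement would separate these two readings.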